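Chloro in Place of Methylsulfanyl: an Expected Partial Recovery

The source may report more compounds than this note shows. Statements on the series, on what has been measured and on what is new or still open speak of the compounds shown alone.

Compound 1 `N#Cc1cc(C(=O)N2CCc3ccccc32)ccc1O` gives 2500 nM in an assay on tissue (RPTEC cells) for inhibition of solute carrier family 22 member 12 (Homo sapiens), read by scintillation counting, with stated times of 15 min and 2 h; on this read-out higher numbers stand for weaker inhibition and lower numbers for stronger inhibition. Compound 2 `CSc1cc(C(=O)N2CCc3ccccc32)cc(C#N)c1O` carries a methylsulfanyl group in place of a hydrogen on an aromatic carbon of that core, and in this assay compound 2 reaches only a limit, > 100000 nM. The step of an at least 40-fold higher number from compound 1 to compound 2 (1.60 log units; beyond the scatter) is therefore bounded by the limit of > 100000 nM in this assay, at which 1 of the 2 values shown sits, so its true size is not known beyond that bound. Compound 3 `N#Cc1cc(C(=O)N2CCc3ccccc32)cc(Cl)c1O` differs from compound 2 by chloro in place of methylsulfanyl on an aromatic carbon. Among the measured compounds shown here, the single measured step that bears on this position is an at least 40-fold higher number from compound 1 to compound 2 (1.60 log units; beyond the scatter): placing methylsulfanyl there weakened inhibition greatly. In compound 3 the methylsulfanyl group leaves but hydrogen does not return, so a number between those of compound 1 and compound 2 is expected, with real uncertainty about whether the limit is escaped. Compound 3 is expected to give about 20000 nM, between 3000 nM and 150000 nM. This amounts to an expected step of an at least 5.0-fold lower number from compound 2 to compound 3 (0.69 log units; beyond the scatter).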

Compound 3, half-maximal inhibitory concentration: 14700 nM
Compound 3: the middle estimate sits 1.4-fold (0.13 log units) above what was measured; low and high end bracket the measured number.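

In this assay compound 3 gives 14700 nM as a real number, which shows that this position, ortho to a hydroxy group, can carry a group other than hydrogen and keep measurable inhibition. Exchanging methylsulfanyl for chloro produces an at least 6.8-fold lower number from compound 2 to compound 3 (0.83 log units; beyond the scatter) and so shows that the loss depends on which group sits there, though the true size of this step cannot be read: the limit of > 100000 nM in this assay, at which 1 of the 3 values shown sits. Chloro still falls short of hydrogen, with a 5.9-fold higher number from compound 1 to compound 3 (0.77 log units; beyond the scatter) in the comparison with the core of compound 1, so neither group tried at this position matches hydrogen.

From the compounds shown here alone, how a fluoro or a methoxy group at this place would compare with chloro and hydrogen remains open. So does whether an amine or a carboxylic acid there would retain any inhibition.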